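Dimethoxy versus trimethoxy anilino sulfonyl quinoxalines against PC-3 cells

The source may report more compounds than this note shows. Statements on the series, on what has been measured and on what is new or still open speak of the compounds shown alone.

Measured compounds:
compound 1 `COc1cc(Nc2nc3ccccc3nc2S(=O)(=O)c2ccccc2)cc(OC)c1OC` — 29100 nM
compound 2 `COc1cc(Nc2nc3ccccc3nc2S(=O)(=O)c2ccc(F)cc2)cc(OC)c1` — 4530 nM

Two compounds have been run in a functional assay on PC-3 cells (Homo sapiens) for cytotoxicity, read by MTT assay, with a stated time of 72 h; on this read-out higher numbers stand for weaker inhibition and lower numbers for stronger inhibition. Going by the values given here, compound 2 gives 4530 nM, the lower of the two numbers; compound 1 gives 29100 nM, the only comparison available, and it lies well beyond the scatter. The two differ in two places at once, so neither change can be assigned its own share.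

Compound 3 `COc1cc(Nc2nc3ccccc3nc2S(=O)(=O)c2ccc(F)cc2)cc(OC)c1OC` is the next to be measured. It differs from compound 2 by methoxy in place of hydrogen on an aromatic carbon, giving the same three-methoxy pattern as compound 1 while keeping the fluorine of compound 2. Among the compounds with values here, no single-change pair is available to size this step. The weak number of compound 1 suggests the added methoxy will not help; a step from compound 2 of a 2.4-fold higher number from compound 2 to compound 3 (0.39 log units; beyond the scatter) toward weaker inhibition is expected, uncertain in size. For compound 3 the estimate is 11000 nM, within 3000 nM to 35000 nM.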

Compound 3, half-maximal inhibitory concentration: > 50000 nM
Compound 3: a limit, no number; the forecaster's own chance of this, stated with the estimate: 5%; middle value at least 4.5-fold (0.65 log units) away from the limit.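

In this assay compound 3 gives > 50000 nM, a limit of the assay and not a number. Methoxy in place of hydrogen, ortho to two methoxy groups and para to a large group, now has a size of its own as a single change: an at least 11-fold higher number from compound 2 to compound 3 (1.04 log units; beyond the scatter), a large step toward weaker inhibition that the two-place comparison of compound 1 and compound 2 could not isolate. The fluoro in place of hydrogen step, an at least 1.7-fold higher number from compound 1 to compound 3 (0.23 log units; that floor lies within the scatter), is only a floor, so the direction and size of any fluoro contribution cannot be read with three methoxy groups present.

As far as these compounds go, whether a hydroxyl, an amine or an ethoxy group at this position would sit closer to hydrogen or to methoxy remains open. Going by these compounds alone, also open is how fluoro in place of hydrogen acts with only two methoxy groups on the ring.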